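Demethylation of a Dienone Chain Ether in a Growth Series

The source may hold more compounds than are shown below. What is called first, only, known or untested is meant among the compounds shown, and "the series" means these compounds.

Within the data shown here, two measured compounds define the series so far. Compound 1 `C/C=C/C=C/C(=O)C[C@H](CCO)OC` gives 49000 nM in a functional assay on HT-29 cells (Homo sapiens) for inhibition (a lower number here means a stronger inhibitor of growth, a higher number a weaker inhibitor of growth), the highest of the two numbers; compound 2 `C/C=C/CCC(=O)C[C@@H](O)CCO[C@]1(CC/C=C/C)C[C@@H](O)CCO1` gives 28000 nM in this assay, and the gap between them lies within the scatter, so neither can be ranked above the other. Among the measured compounds shown here, no step between single-point variants has been characterised.

Compound 3 `C/C=C/C=C/C(=O)C[C@@H](O)CCO` is yet to be measured. Relative to compound 1 it carries hydrogen in place of methyl on an oxygen on a saturated carbon, which one bond further out reads as methoxy to hydroxy. With no comparable step on record, the expectation for compound 3 rests only on the weak growth inhibition shown by compound 1 at 49000 nM and by compound 2 at 28000 nM: a step of a 1.2-fold lower number from compound 1 to compound 3 (0.09 log units; within the scatter) of no size beyond the scatter is estimated, in either direction. Compound 3 is therefore expected to give about 40000 nM in this assay, within a range from 15000 nM to 120000 nM.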

Compound 3, concentration for 50% growth inhibition: 54000 nM
The estimate for compound 3 lay 1.4-fold (0.13 log units) below the measured number; measured number inside the range.
By their numbers in this assay, from the lowest: compounds 2, 1 and 3 (each within the scatter of the next).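

Methoxy to hydroxy, on an oxygen on a saturated carbon, is the first single-place change on record for the series in this assay, and it reads as a 1.1-fold higher number from compound 1 to compound 3 (0.04 log units; within the scatter). The methyl on this oxygen can therefore give way to hydrogen with no step beyond the scatter, so this difference does not separate compound 1 from compound 3 in growth inhibition. Nothing on hand bears on the reason for this result.

From the compounds shown here alone, whether an ethoxy group, a longer alkoxy chain, an amine or a carboxylic acid at this place would give a step beyond the scatter stays open. Also open, going by these compounds, is whether any single-place change on this chain can bring a number in this assay clearly below those of compound 1 and compound 3.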